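Trifluoromethyl for fluoromethyl on the carbamate oxygen

The source may report more compounds than this note shows. Statements on the series, on what has been measured and on what is new or still open speak of the compounds shown alone.

Of the compounds shown here, two sharing one core have been measured in a functional assay on isolated protein for inhibition of Glucose-dependent insulinotropic receptor (Rattus norvegicus), read by HTRF and cAMP accumulation; a lower number here means that less compound is needed, a higher number that more compound is needed for the effect. Compound 1 `Cc1nc(S(C)(=O)=O)ccc1Oc1ncnc(OC2CCN(C(=O)OC(C)(C)C#N)CC2)c1F` gives 1320 nM. Compound 2 `Cc1nc(S(C)(=O)=O)ccc1Oc1ncnc(OC2CCN(C(=O)O[C@H](C)CF)CC2)c1F` gives 1520 nM; this is the higher of the two numbers, yet the step of a 1.2-fold higher number from compound 1 to compound 2 (0.06 log units; within the scatter) lies within the scatter, so the two compounds cannot be ordered. Compound 3 `Cc1nc(S(C)(=O)=O)ccc1Oc1ncnc(OC2CCN(C(=O)O[C@@H](C)C(F)(F)F)CC2)c1F` is not yet measured. It differs from compound 2 in one place: 1-(trifluoromethyl)ethyl in place of 1-(fluoromethyl)ethyl on an oxygen next to a carbonyl group. Going by the values given here, the only measured step that bears on this position is a 1.2-fold higher number from compound 1 to compound 2 (0.06 log units; within the scatter), where a change of the group on the same oxygen next to the carbonyl left the number within the scatter. On that basis the step from compound 2 to compound 3 is expected to be small, a 1.0-fold lower number from compound 2 to compound 3 (0.01 log units; within the scatter), with no direction beyond the scatter. Compound 3 is therefore estimated at 1500 nM in this assay, between 600 nM and 3800 nM.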

Compound 3, half-maximal effective concentration: 109 nM
Estimate against measurement, compound 3: 14-fold (1.14 log units) above, and the stated range ends above it.
By their numbers in this assay, from the lowest: compound 3; then compounds 1 and 2 (each within the scatter of the next).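

In this assay the group on an oxygen next to a carbonyl group turns out to matter: 1-(trifluoromethyl)ethyl in place of 1-(fluoromethyl)ethyl gives a 14-fold lower number from compound 2 to compound 3 (1.14 log units; beyond the scatter) as a large step, and in place of 1-cyano-1-methylethyl it gives a 12-fold lower number from compound 1 to compound 3 (1.08 log units; beyond the scatter) as a second large step. Going by these compounds alone, the earlier pair showed only that two groups could be exchanged here within the scatter, so its flat result did not mean that the position is indifferent to every change. Compound 3 now stands clearly apart from both compound 1 and compound 2, which remain level with each other.

Where a 1-(difluoromethyl)ethyl group or a longer chain such as 1-(pentafluoroethyl)ethyl would fall remains open. Nothing shown here accounts for the size of these steps.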